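The source may report more compounds than this note shows. Statements on the series, on what has been measured and on what is new or still open speak of the compounds shown alone.

Compound 1 `CCOC(=O)C1=C(Nc2ccccc2)S/C(=C\c2ccccc2)C1=O` gives 29.6% in a functional assay on A549 cells (Homo sapiens) for inhibition, read by MTT assay, with a stated time of 72 h, tested at 10 uM; a lower number here means less inhibition, a higher number more inhibition at the concentration tested (going by the name of the read-out). Compound 2 `CCOC(=O)C1=C(Nc2ccccc2)S/C(=C\c2ccc[nH]2)C1=O` gives 23.5% in this assay, and a number 6.1 percentage points lower from compound 1 to compound 2 (within the scatter). Compound 3 `CCOC(=O)C1=C(Nc2ccccc2)S/C(=C\c2cc[nH]c2)C1=O` gives in this assay only a limit, < 10%, and no number (the limit of < 10% in this assay, at which 1 of the 3 values shown sits). Even so, a number at least 19.6 percentage points lower from compound 1 to compound 3 (beyond the scatter) and a number at least 13.5 percentage points lower from compound 2 to compound 3 (beyond the scatter), so compound 3 stands at the lowest point of what has been measured, with only a limit to mark where it sits.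

Compound 4 `CCOC(=O)C1=C(Nc2ccccc2)S/C(=C\c2cccnc2)C1=O` has not yet been measured in this assay. It differs from compound 3 in one place: pyridin-3-yl in place of 1H-pyrrol-3-yl on a double-bonded chain carbon bound to a double-bonded ring carbon. The measured steps that bear on this change are the two that lead into compound 3, a number at least 19.6 percentage points lower from compound 1 to compound 3 (beyond the scatter) and a number at least 13.5 percentage points lower from compound 2 to compound 3 (beyond the scatter), both beyond the scatter and both downward onto the limit, whereas compound 1 with phenyl and compound 2 with 1H-pyrrol-2-yl at the same place both gave numbers. Going by the values given here, an upward step is therefore expected, a number at least 12 percentage points higher from compound 3 to compound 4 (beyond the scatter), though its size is uncertain since compound 3 stands only at a limit and no measured step describes pyridin-3-yl at that place. Compound 4 is estimated at 22%, within a range from 8% to 40%.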

Compound 4, a percentage reported as inhibition, at one concentration (the size of the read-out at that concentration, not a potency): < 10%
Compound 4: no number, only a limit; the forecaster's own chance of this, stated with the estimate: 20%; at least 12 percentage points between middle value and limit.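

At this place, on a double-bonded chain carbon bound to a double-bonded ring carbon, pyridin-3-yl in place of phenyl gives a number at least 19.6 percentage points lower from compound 1 to compound 4 (beyond the scatter), and pyridin-3-yl in place of 1H-pyrrol-2-yl gives a number at least 13.5 percentage points lower from compound 2 to compound 4 (beyond the scatter). The earlier compounds shown here showed such a fall only with 1H-pyrrol-3-yl, whereas it now also appears with pyridin-3-yl, a group that differs from 1H-pyrrol-3-yl in ring size and in its hydrogen-bond donors and acceptors. The step between compound 3 and compound 4 cannot be read, and in this assay both compounds stand only at a limit: the limit of < 10% in this assay, at which 2 of the 4 values shown sit.

As far as these compounds go, how far compound 3 and compound 4 lie under that limit stays open, and with it any order between the two. From the compounds shown here alone, it also stays open whether pyridin-4-yl, furan-2-yl or a phenyl ring carrying an amine or a carboxylic acid at this place would give a number like those of compound 1 and compound 2.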